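The compounds below may be only part of what the source reports. "The series", "measured", "known", "first", "only" and "open" are said of these compounds alone.

Among the compounds with values here, compound 1 `O=C(CCc1ccccc1)NNc1c(Cl)cncc1Cl` gives 650 nM in a functional assay on HEK293 cells for antagonist activity at P2X purinoceptor 7 (Homo sapiens), read by fluorescence, with a stated time of 2 h (a higher number here means a weaker inhibitor, a lower number a stronger inhibitor), and stands at the lower of the two numbers measured so far. Compound 2 `Cc1cccc(C)c1NNC(=O)CCc1ccccc1` gives 900 nM in this assay; the two values lie within the scatter of each other. Compound 3 `O=C(CCc1ccc(Cl)cc1)NNc1c(Cl)cncc1Cl` differs from compound 1 in one place: chloro in place of hydrogen on an aromatic carbon. Within the data shown here, no step between measured compounds covers this change. In this assay the expected step is a 1.6-fold lower number from compound 1 to compound 3 (0.21 log units; within the scatter), small and toward a lower number, or none beyond the scatter. Compound 3 is accordingly estimated at 400 nM, with a range from 150 nM to 1100 nM.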

Compound 3, half-maximal inhibitory concentration: 1100 nM
For compound 3 the middle estimate is 2.8-fold (0.44 log units) below the measured one; the measured number falls inside the stated range.
By their numbers in this assay, from the lowest: compounds 1, 2 and 3 (each within the scatter of the next).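

Phenyl to 4-chlorophenyl on the core of compound 1 gives a 1.7-fold higher number from compound 1 to compound 3 (0.23 log units; within the scatter) in this assay and so no change beyond the scatter. Within the data shown here, compounds 1 and 2 both carry an unsubstituted phenyl, so this is the first reading of a group on that ring, and this position accepts a chloro with potency held in the same range. Nothing at hand bears on why the step has this size.

From the compounds shown here alone, whether a methoxy, an amine or a carboxylic acid at this place would behave like chloro remains open. Also open, going by these compounds, are the same chloro on compound 2 and a longer chain carrying the phenyl.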